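The source may hold more compounds than are shown below. What is called first, only, known or untested is meant among the compounds shown, and "the series" means these compounds.

Compound 2, structure `C[N+](C)(CCCC(=O)[O-])CC1CCC1`, stands at the weak end of what has been measured: in an assay for inhibition of gamma-butyrobetaine dioxygenase (Homo sapiens), read by HPLC, with stated times of 15 min and 30 min (on this read-out lower numbers stand for stronger inhibition and higher numbers for weaker inhibition), compound 2 gives only a limit, > 1000000 nM, and no number. Compound 1, structure `CC[N+](C)(CC)CCCC(=O)[O-]`, in this assay gives 100000 nM. Compound 3, structure `C[N+](C)(CCl)CCCC(=O)[O-]`, differs from compound 2 by chloro in place of cyclobutyl on a saturated chain carbon bound to an amine nitrogen. Among the compounds with values here, no measured step of this kind exists, so the expectation rests on compound 1 and the limit of compound 2 alone; the step of an at least 20-fold lower number from compound 2 to compound 3 (1.30 log units; beyond the scatter) is expected to run toward stronger inhibition, its size uncertain. For compound 3 in this assay the estimate is 50000 nM, within 10000 nM to 500000 nM.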

Compound 3, half-maximal inhibitory concentration: 268000 nM
Estimate against measurement, compound 3: 5.4-fold (0.73 log units) below; the range from low to high includes it.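

Chloro in place of cyclobutyl on a saturated chain carbon bound to an amine nitrogen gives the first step readable at this place in this assay: an at least 3.7-fold lower number from compound 2 to compound 3 (0.57 log units; beyond the scatter). This place therefore accepts a change that moves the series from a limit to a number. The size of the step is only a minimum, because compound 2 gives a limit and no number: the limit of > 1000000 nM in this assay, at which 1 of the 3 values shown sits.

The compounds shown leave open whether chloro itself or the loss of the cyclobutyl ring carries the step. Going by these compounds, how fluoro, hydroxyl or a plain methyl at this place would read also stays open.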